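The source may hold more compounds than are shown below. What is called first, only, known or untested is meant among the compounds shown, and "the series" means these compounds.

Series notes on the ester variation. Compound 1 `CCCC(=O)OC1CCC(CN2CCN(c3cc(=O)c4cc(C(F)(F)F)cc([N+](=O)[O-])c4s3)CC2)CC1` carries a propyl on the carbonyl carbon of the ester. In an ADME assay on Vero cells (Chlorocebus sabaeus) for cytotoxicity, read by MTT assay, with a stated time of 48 h (a higher number here means a weaker inhibitor, a lower number a stronger inhibitor), compound 1 gives only a limit, > 64 ug/mL. Compound 2 `O=C(OC1CCC(CN2CCN(c3cc(=O)c4cc(C(F)(F)F)cc([N+](=O)[O-])c4s3)CC2)CC1)C1CCC1` has cyclobutyl in place of propyl on that carbonyl carbon. In this assay compound 2 likewise gives only a limit, > 64 ug/mL. The step that the two limits leave unreadable from compound 1 to compound 2 is therefore unreadable, and compound 2 stands simply at the limit of > 64 ug/mL in this assay, at which 2 of the 2 values shown sit, with nothing further to place it. Among the measured compounds shown here, compound 3 `O=C(OC1CCC(CN2CCN(c3cc(=O)c4cc(C(F)(F)F)cc([N+](=O)[O-])c4s3)CC2)CC1)c1ccc2c(c1)OCC2` is the next variation: a group of 9 heavy atoms (8 carbon, 1 oxygen; one five-membered non-aromatic ring with 1 hetero atom, one six-membered aromatic ring of carbon only) in place of a group of 4 heavy atoms (4 carbon; one four-membered non-aromatic ring of carbon only), on a carbonyl carbon The single measured step gives no usable size or direction for changes on this carbonyl carbon, so no shift beyond the scatter is expected. The estimate for compound 3 in this assay is 90 ug/mL, in the range 45 ug/mL to 250 ug/mL. The expected step that the limit leaves unreadable from compound 2 to compound 3 is none beyond the scatter, and the assay is most likely to report a limit once more.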

Compound 3, half-maximal inhibitory concentration: > 64 ug/mL
Compound 3 gave a limit, no number (the forecaster's own chance of this, stated with the estimate: 75%); the middle value is on the limit's open side.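

In this assay compound 3 gives only a limit, > 64 ug/mL. Among the compounds shown here, no step among compound 1, compound 2 and compound 3 can be read, as all sit at one limit: the limit of > 64 ug/mL in this assay, at which 3 of the 3 values shown sit. The compounds shown leave open how far their true values in this assay differ.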